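The compounds below may be only part of what the source reports. "The series", "measured", "known", "first", "only" and "open" are said of these compounds alone.

Measured so far in an ADME assay on Huh-7 cells (Homo sapiens) for cytotoxicity, read by MTT assay; on this read-out higher numbers stand for lower toxicity in this test and lower numbers for higher toxicity in this test:
Compound 1 `CS(=O)(=O)N(CCCCCCN1C[C@H](O)[C@@H](O)[C@H](O)[C@H]1CO)C1CCCCC1` gives > 500000 nM, which is a limit of the assay and not a number.
Compound 2 `NC(=O)N(CCCCCCN1C[C@H](O)[C@@H](O)[C@H](O)[C@H]1CO)C1CCCCC1` gives > 500000 nM, again a limit of the assay.

Within the data shown here, the only step between measured compounds, a step that the two limits leave unreadable from compound 1 to compound 2, runs between two limits and so cannot be sized. Compound 2 thus stands at the limit of > 500000 nM in this assay, at which 2 of the 2 values shown sit; no number places it inside the range the assay resolves.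

Compound 3 `CCCNC(=O)N(CCCCCCN1C[C@H](O)[C@@H](O)[C@H](O)[C@H]1CO)C1CCCCC1` differs from compound 2 by propyl in place of hydrogen on an amide-type nitrogen. Among the measured compounds shown here, no measured step bears directly on this change, and the one step available, a step that the two limits leave unreadable from compound 1 to compound 2, is itself unreadable. Both measured values sit at the limit of > 500000 nM in this assay, at which 2 of the 2 values shown sit, and compound 3 is expected to remain there as well. The step of a number no higher from compound 2 to compound 3 (the limit leaves the size open) is the expected size, which is none beyond the scatter. Compound 3 is expected at 500000 nM, in a range of 250000 nM to 1000000 nM, most likely reported as a limit again.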

Compound 3, half-maximal cytotoxic concentration: > 500000 nM
Compound 3 was reported as a limit; the forecaster's own chance of this, stated with the estimate: 80%; the middle value lies on the limit itself.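

In this assay compound 3 gives > 500000 nM, a limit of the assay and not a number. Among these compounds, no step among compound 1, compound 2 and compound 3 can be read: the limit of > 500000 nM in this assay, at which 3 of the 3 values shown sit. The compounds shown leave open whether any of these changes shifts cytotoxicity in this assay at all.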